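Methoxy on the styryl ring of compound 1

A few compounds are considered here, and "the series" means these few. Any claim that something is new, unique, unknown or untested is made for them only; others in the source may bear on it.

- compound 1 `CC1(/C=C/c2ccccc2)C=CC(=O)O1` gives 95300 nM
- compound 2 `COc1ccccc1/C=C/C1(C)C=CC(=O)O1` gives 27000 nM

In a functional assay on MCF7 cells (Homo sapiens) for inhibition, read by sulforhodamine B assay, with a stated time of 48 h (on this read-out lower numbers stand for stronger inhibition of growth and higher numbers for weaker inhibition of growth), compound 1 stands at the higher of the two numbers, which makes it the weaker growth inhibitor of the pair. Going by the values given here, one measured step bears on what follows: a 3.5-fold lower number from compound 1 to compound 2 (0.55 log units; beyond the scatter). This modest step is methoxy in place of hydrogen on an aromatic carbon.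

Compound 3 `COc1ccc(/C=C/C2(C)C=CC(=O)O2)cc1` has not yet been measured. Its structure departs from that of compound 1 by methoxy in place of hydrogen on an aromatic carbon. This is the same kind of exchange as in compound 2, but on a different carbon of the aromatic ring. A single step cannot show how much that difference matters, so it is only a rough guide. A modest step toward a lower number in this assay is therefore expected, similar to or somewhat smaller than the one measured. The estimated change is a 2.5-fold lower number from compound 1 to compound 3 (0.40 log units; beyond the scatter). For compound 3 the expected value is 38000 nM, with an estimated range from 14000 nM to 95000 nM.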

Compound 3, concentration for total growth inhibition: 183000 nM
Beside the measured number, compound 3's estimate is 4.8-fold (0.68 log units) below it; the whole stated range lies below it.
By their numbers in this assay, from the lowest: compound 2; then compounds 1 and 3 (each within the scatter of the next).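

With methoxy in place of hydrogen on an aromatic carbon, para to a group of 9 heavy atoms, this assay gives a 1.9-fold higher number from compound 1 to compound 3 (0.28 log units; within the scatter), so at this position the exchange cannot be told apart from no change at all. The same exchange on a different carbon of the ring gave a 3.5-fold lower number from compound 1 to compound 2 (0.55 log units; beyond the scatter), which shows that, among these three compounds, the earlier step does not carry over to every carbon of the ring and that the place of the methoxy matters as well as its presence. Nothing available here explains why the two carbons of the ring part ways.

The three compounds leave open whether the step seen for compound 2 belongs to methoxy itself or would also appear with another group on that carbon, such as hydroxyl, a chlorine atom or an amine. They also leave open whether a group such as a carboxylic acid or a longer alkoxy chain, para to the group of 9 heavy atoms, would move the number beyond the scatter where methoxy does not.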